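This account rests on a few compounds, and the source may have more. Where it says the series, first, only, none or still open, it means among the compounds named here.

Measured so far in an assay on membranes from HEK293 cells for displacement of a labelled ligand from adenosine receptor A2b (Homo sapiens), read by scintillation counting, with a stated time of 30 min, tested at 1 uM; on this read-out lower numbers stand for less inhibition and higher numbers for more inhibition at the one concentration tested (going by the name of the read-out):

compound 1 `CCCOC(=O)C1=C(C)N(C)C(=O)NC1c1ccoc1`: 2%
compound 2 `CC1=C(C(=O)OC(C)(C)C)C(c2ccoc2)NC(=O)N1C`: 16%

Two compounds share the core of compound 1 and differ only in the ester group. In this assay compound 1 gives 2% and compound 2 gives 16%. For the measured compounds named here, the single measured step, tert-butyl in place of propyl on an oxygen next to a carbonyl group, reads a number 14 percentage points higher from compound 1 to compound 2 (beyond the scatter). On these two numbers compound 2 stands highest; its nearest neighbour is compound 1, lower by a margin beyond the scatter.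

Compound 3 `CC1=C(C(=O)OC(C)(C)C)C(c2cccs2)NC(=O)N1C` keeps the tert-butyl ester of compound 2 and differs from it in one place: thiophen-2-yl in place of furan-3-yl on a saturated ring carbon. Going by the values given here, no measured step bears on this change. Among the compounds with values here, the only step in hand concerns the ester, not the ring on the saturated ring carbon, so it gives no guide to direction or size here. Without any relevant precedent, the working expectation for compound 3 is no step beyond the scatter: no change at the digits printed from compound 2 to compound 3 (within the scatter) is the estimated step. Compound 3 is accordingly estimated at 16% in this assay, with a range from 2% to 35%, the width reflecting the absence of any comparable step among the measured compounds.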

Compound 3, a percentage reported as inhibition, at one concentration (the size of the read-out at that concentration, not a potency): 24%
For compound 3 the middle estimate is 8 percentage points below the measured one; the measured number falls inside the stated range.
By their numbers in this assay, from the lowest: compound 1; then compounds 2 and 3 (each within the scatter of the next).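

In this assay, for the compounds shown here, thiophen-2-yl in place of furan-3-yl on a saturated ring carbon gives a number 8 percentage points higher from compound 2 to compound 3 (within the scatter), the first reading at this position with the tert-butyl ester held fixed. The ring on this carbon can therefore pass from furan-3-yl to thiophen-2-yl, with sulfur taking the place of oxygen and the ring name changing from the 3-yl to the 2-yl form, without a shift that this read-out can separate from the scatter, although this single step does not separate the exchange of hetero atom from the change in point of attachment. No available measurement speaks to the reason for this result, or to any property of either ring.

Still open, from the compounds shown here alone, is whether a larger or differently built group on the same carbon, such as phenyl, pyridin-3-yl or a ring carrying a carboxylic acid or an amine, would move the number beyond the scatter. Also open, going by these compounds, is whether the ester step seen with furan-3-yl, a number 14 percentage points higher from compound 1 to compound 2 (beyond the scatter), holds with thiophen-2-yl on this carbon, and whether a single reading at one concentration reflects the order that full concentration curves would give.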